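The compounds below may be only part of what the source reports. "The series", "measured", "known", "first", "only" and "open" are said of these compounds alone.

Measured so far:
- compound 1 `O=C(Nc1ccc(-n2ccc3nc(C(=O)NCc4ccccc4)ccc32)cc1)Nc1ccc(Cl)c(C(F)(F)F)c1`: 1100 nM in a functional assay on A375P cells (Homo sapiens) for cytotoxicity, read by MTT assay; a lower number here means a stronger inhibitor, a higher number a weaker inhibitor
- compound 2 `COC(=O)c1ccc2c(ccn2-c2ccc(NC(=O)c3ccc(Cl)c(C(F)(F)F)c3)cc2)n1`: 3000 nM in this assay
- compound 3 `COC(=O)c1ccc2c(ccn2-c2cccc(NC(=O)Nc3cccc(C(F)(F)F)c3)c2)n1`: > 10000 nM in this assay, a limit of the assay rather than a number

Among the values that are numbers, compound 2 stands highest in this assay; its nearest neighbour is compound 1, whose value sits lower by a gap beyond the scatter. For compound 3 the assay reports only a limit, and (the limit of > 10000 nM in this assay, at which 1 of the 3 values shown sits).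

The unmeasured compound 4 `COC(=O)c1ccc2c(ccn2-c2ccc(NC(=O)c3cccc(C(F)(F)F)c3)cc2)n1` differs from compound 2 in one place: hydrogen in place of chloro on an aromatic carbon, so the 4-chloro-3-(trifluoromethyl)phenyl becomes 3-(trifluoromethyl)phenyl. Among the measured compounds shown here, no measured pair shows this same change. Compound 3, which also carries the 3-(trifluoromethyl)phenyl, reaches only a limit, though it differs from compound 2 in more than this one place, so it cannot settle the question.

The expectation for compound 4 is a weakening in this assay, a step of a 2.7-fold higher number from compound 2 to compound 4 (0.43 log units; beyond the scatter). Compound 4 is therefore estimated at 8000 nM, within 3000 nM to 20000 nM.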

Compound 4, half-maximal inhibitory concentration: 9500 nM
For compound 4 the middle estimate is 1.2-fold (0.07 log units) below the measured one, within the range that was stated.
By their numbers in this assay, from the lowest: compound 1; then compound 2; then compound 4. At a limit, above all of these: compound 3.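

In this assay, replacing the chloro with hydrogen on this aromatic carbon, ortho to a trifluoromethyl group, gives a 3.2-fold higher number from compound 2 to compound 4 (0.50 log units; beyond the scatter). Among the compounds shown here, the earlier compounds offered no pair isolating this position; this step shows that the chloro contributes to the cytotoxic potency on its own, apart from the other differences among the compounds, though this holds for only one pair, on the background of compound 2. No measurement shown accounts for why the loss of the chloro weakens the compound.

Going by these compounds, whether the same change has a similar effect in the urea series, to which compound 1 belongs, remains open. So does the effect of placing a fluoro, a methyl or a methoxy group on this carbon instead of chloro or hydrogen.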